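The source may report more compounds than this note shows. Statements on the series, on what has been measured and on what is new or still open speak of the compounds shown alone.

Of the compounds shown here, two have been tested in a toxicity assay on SW-620 cells (Homo sapiens) for cytotoxicity, read by MTT assay, with a stated time of 48 h (on this read-out higher numbers stand for weaker inhibition and lower numbers for stronger inhibition), and both sit at the edge of what the assay can report. Compound 1, `COc1cc(C)c(C(=O)N[C@@H]2[C@@H](C)O[C@@H](O[C@H]3CC[C@H](C)[C@@H]4[C@@H]3C=C(C)[C@H]3/C(C)=C/CC/C(C)=C/[C@@H]5C=C(C(=O)O)[C@H](C)C[C@]56OC(=O)C(=C6O)C(=O)[C@@]43C)[C@H](O)[C@]2(C)O)c(O)c1`, gives in this assay a value of > 30000 nM, which is a limit of the assay rather than a number. Compound 2, `COc1cc(C)c(C(=O)O[C@H]2[C@@H](O)[C@@H](O)[C@H](O[C@H]3CC[C@H](C)[C@@H]4[C@@H]3C=C(C)[C@H]3/C(C)=C/CC/C(C)=C/[C@]5(C)C=C(C(=O)O)[C@H](C)C[C@]56OC(=O)C(=C6O)C(=O)[C@@]43C)O[C@@H]2C)c(O)c1`, likewise gives in this assay > 30000 nM, again a limit and not a measured number. Within the data shown here, compound 2 therefore stands at the limit of > 30000 nM in this assay, at which 2 of the 2 values shown sit, so its position on the scale is known only as a limit, and no step between measured compounds can be drawn from it.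

Compound 3, `COc1cc(C)c(C(=O)O[C@H]2[C@@H](O)[C@@H](O)[C@H](O[C@H]3CC[C@H](C)[C@@H]4[C@@H]3C=C(C)[C@H]3/C(C)=C/CC/C(C)=C/[C@]5(C)C=C(C(=O)O)[C@H](C)C[C@]56OC(=O)C(=C6O)C(=O)[C@@]43C)O[C@@H]2C)c(OC)c1`, is the next compound to be measured in this assay. It differs from compound 2 in one place: methyl in place of hydrogen on an oxygen on an aromatic ring. Among the measured compounds shown here, with compound 2 known only as a limit, no step between measured compounds is available to guide the expectation, and the change itself is small. The author expects no step beyond the scatter from compound 2 to compound 3, that is a step that the limit leaves unreadable from compound 2 to compound 3. Compound 3 is accordingly expected to give about 40000 nM, within a range from 15000 nM to 120000 nM, most likely again reported as a limit.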

Compound 3, half-maximal inhibitory concentration: > 30000 nM
Compound 3: only a limit was reported (the forecaster's own chance of this, stated with the estimate: 85%); the middle value does not contradict the limit.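

Compound 2 and compound 3 both give a limit of the assay rather than a number, so no step can be read for the change from hydroxy to methoxy. The compounds shown leave open whether any of them, or any change to the shared core, would give a measurable value in this assay: the limit of > 30000 nM in this assay, at which 3 of the 3 values shown sit.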